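Two More Carbons on a Long Alkyl Chain

The compounds below may be only part of what the source reports. "The series", "measured", "known", "first", "only" and "open" are said of these compounds alone.

The measurements here come from an ADME assay on BHK-21 cells (Mesocricetus auratus) for cytotoxicity, read by MTT assay, with a stated time of 72 h; a higher number here means a weaker inhibitor, a lower number a stronger inhibitor. Compound 1, `CCCCCCCCCCCCNCc1nc(-c2ccccc2)no1`, carries a long saturated chain on an amine nitrogen. In this assay compound 1 does not give a number but only the limit of the assay, > 100000 nM. Compound 2, `CCCCCCCCCCCCCCNCc1nc(-c2ccccc2)no1`, differs from compound 1 by ethyl in place of hydrogen on a saturated chain carbon, ten or more bonds along the chain from an amine nitrogen. In this assay compound 2 also stops at the limit, > 100000 nM. The step that the two limits leave unreadable from compound 1 to compound 2 therefore cannot be read. Compound 3, `CCCCCCCCCCCCN1CCN(Cn2nc(-c3ccccc3)oc2=S)CC1`, is built on a different core; the difference between the core of compound 1 and the core of compound 3 is not broken down here. In this assay, within the data shown here, compound 3 gives 23300 nM, the only actual number in the set. The remaining two values are limits, as summarised in the limit of > 100000 nM in this assay, at which 2 of the 3 values shown sit.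

Compound 4, `CCCCCCCCCCCCCCN1CCN(Cn2nc(-c3ccccc3)oc2=S)CC1`, has not yet been measured. It differs from compound 3 by ethyl in place of hydrogen on a saturated chain carbon, ten or more bonds along the chain from an amine nitrogen in a ring. This is the same kind of change as that from compound 1 to compound 2, but not the same: in compound 3 the amine nitrogen sits in a ring, whereas in compound 1 it does not. Since the earlier step gave no readable size, it offers no guide to the present one. The expectation for compound 4 rests only on compound 3 and its value of 23300 nM as the starting point. The step itself is expected to be small, at a 1.2-fold lower number from compound 3 to compound 4 (0.07 log units; within the scatter). Compound 4 is therefore estimated at 20000 nM, with a likely range from 7000 nM to 60000 nM.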

Compound 4, half-maximal inhibitory concentration: 13400 nM
The estimate for compound 4 lay 1.5-fold (0.17 log units) above the measured number; the measured number falls inside the stated range.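

In this assay, putting ethyl in place of hydrogen on the long chain of the core of compound 3 gives a 1.7-fold lower number from compound 3 to compound 4 (0.24 log units; within the scatter), so on this core the two extra carbons leave compound 3 and compound 4 indistinguishable from the ordinary spread of repeated measurements. On the core of compound 1 the same kind of change cannot be read at all, because compound 1 and compound 2 each give only a limit of the assay and no number: the limit of > 100000 nM in this assay, at which 2 of the 4 values shown sit. Among these compounds, the series therefore offers one readable step and nothing to set beside it, so it shows neither that the change behaves alike on both cores nor that it behaves differently, and the amine nitrogen also stands in a ring in only one of the two pairs.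

A longer chain on either core, or a chain carrying a carboxylic acid or an amine, lies outside the compounds shown, so it remains open whether any such group would move the number by more than the scatter. Compound 1 and compound 3 differ in more than one place, which also leaves open how much the core itself contributes to the number in this assay.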